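Trading a side chain for hydrogen in compound 2

This account rests on a few compounds, and the source may have more. Where it says the series, first, only, none or still open, it means among the compounds named here.

- compound 1 `COC[C@H](NC(=O)[C@H](CSC)NC(=O)c1cc(Cl)ccc1Cl)C(=O)N[C@@H](CC(C)C)C(=O)[C@@]1(C)CO1`: < 0.0834 h (a limit)
- compound 2 `COC[C@H](NC(=O)c1cc(C)on1)C(=O)N[C@@H](CSC)C(=O)N[C@@H](CC(C)C)C(=O)[C@@]1(C)CO1`: 0.202 h
- compound 3 `CSC[C@H](NC(=O)c1cc(C)on1)C(=O)N[C@@H](CSC)C(=O)N[C@@H](CC(C)C)C(=O)[C@@]1(C)CO1`: 0.085 h

In an ADME assay on microsomes from liver (Mus musculus) for metabolic stability (a lower number here means that the compound disappears faster, a higher number that the compound lasts longer), compound 2 holds the higher of the two true numbers, at 0.202 h. Compound 1 gives only a limit, < 0.0834 h.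

Compound 4 `COC[C@H](NC(=O)c1cc(C)on1)C(=O)NCC(=O)N[C@@H](CC(C)C)C(=O)[C@@]1(C)CO1` is compound 2 with one change: hydrogen in place of (methylsulfanyl)methyl on a saturated chain carbon bound to an amide-type nitrogen and a carbonyl carbon. Hydrogen stands in place of (methylsulfanyl)methyl on a saturated chain carbon bound to an amide-type nitrogen and a carbonyl carbon.

Among the measured compounds shown here, only one measured step offers guidance. Methylsulfanyl in place of methoxy gave a 2.4-fold lower number from compound 2 to compound 3 (0.38 log units; beyond the scatter). That modest step involves a methylsulfanyl group entering, whereas here one leaves, so a small rise in this assay seems more likely than a fall. One step is thin support for a different change, however, so no shift beyond the scatter is expected. The expected change is a 1.2-fold higher number from compound 2 to compound 4 (0.09 log units; within the scatter). For compound 4 the estimated half-life is 0.25 h, with an expected range from 0.11 h to 0.55 h.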

Compound 4, half-life: 2.06 h
Compound 4: middle estimate off by 8.2-fold (0.92 log units), on the low side; measured number above the stated range.
By their numbers in this assay, from the lowest: compound 3; then compound 2; then compound 4. At a limit, below all of these: compound 1.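

On this saturated chain carbon, bound to an amide-type nitrogen and a carbonyl carbon, the side chain has a strong bearing on the half-life: in this assay, hydrogen in place of (methylsulfanyl)methyl gives a 10-fold higher number from compound 2 to compound 4 (1.01 log units; beyond the scatter). The earlier step, a 2.4-fold lower number from compound 2 to compound 3 (0.38 log units; beyond the scatter), concerned a different place and a methylsulfanyl group entering, and it was much smaller. Both steps from compound 2 now point the same way, with the number falling where methylsulfanyl enters and rising where (methylsulfanyl)methyl leaves, but no measurement shown explains why.

The compounds shown cannot separate the effect of the sulfur from that of having any side chain on this carbon, a question that a plain methyl or a longer carbon chain there could address. From the compounds shown here alone, whether the same change would give a similar step with methylsulfanyl in place of methoxy also remains open.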